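Pentyl ether of the lactone alcohol: expected step in growth inhibition

A few compounds are considered here, and "the series" means these few. Any claim that something is new, unique, unknown or untested is made for them only; others in the source may bear on it.

Measured compounds and values:
compound 1 `COc1ccc2cc(CCCO)oc(=O)c2c1` — 25.8 ug/mL
compound 2 `CCCCCOCCCc1cc2ccc(OC)cc2c(=O)o1` — 6 ug/mL
compound 3 `COc1ccc2c(c1)C(=O)OC(CCCO)C2` — 80.8 ug/mL

All three were read in a functional assay on MCF7 cells (Homo sapiens) for antiproliferative activity, read by sulforhodamine B assay, with a stated time of 48 h; a higher number here means a weaker inhibitor of growth, a lower number a stronger inhibitor of growth. Compound 3 gives the highest number of the three in this assay; compound 2 the lowest. The difference between the core of compound 1 and the core of compound 3 is not broken down here.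

From compound 1 to compound 2 the change is pentyl in place of hydrogen on an oxygen on a saturated carbon, and the step was a 4.3-fold lower number from compound 1 to compound 2 (0.63 log units; beyond the scatter). Compound 4 `CCCCCOCCCC1Cc2ccc(OC)cc2C(=O)O1` is not yet measured; it differs from compound 3 by pentyl in place of hydrogen on an oxygen on a saturated carbon, the same change at the same place. Among the compounds with values here, the step from compound 3 to compound 4 in this assay is therefore expected to be of about the same size, a 4.0-fold lower number from compound 3 to compound 4 (0.61 log units; beyond the scatter), resting on the single earlier pair. For compound 4 an estimate of 20 ug/mL is made, with a range of 8 ug/mL to 50 ug/mL.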

Compound 4, concentration for 50% growth inhibition: 32.3 ug/mL
The estimate for compound 4 lay 1.6-fold (0.21 log units) below the measured number, within the range that was stated.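

Pentyl in place of hydrogen on an oxygen on a saturated carbon again gave a stronger inhibitor of growth in this assay, a 2.5-fold lower number from compound 3 to compound 4 (0.40 log units; beyond the scatter). The change therefore carried from one core to the other in direction, and the two steps cannot be told apart in size: the same change on two cores in this assay, a 4.3-fold lower number (0.63 log units; beyond the scatter) from compound 1 to compound 2 and a 2.5-fold lower number (0.40 log units; beyond the scatter) from compound 3 to compound 4, 1.7-fold (0.24 log units) apart, within the scatter of two such steps

Within the data shown here, this agreement rests on only two pairs, one ether and one assay, so it does not show that the step would hold on further cores, and it gives no cause for the step.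

The compounds shown leave open whether a butyl or octyl ether would give a step of similar size. They also leave open how an amine or a carboxylic acid in place of the hydroxy would read on either core.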